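The source may hold more compounds than are shown below. What is called first, only, known or untested is meant among the compounds shown, and "the series" means these compounds.

In a functional assay on MT4 cells (Homo sapiens) for cytotoxicity, read by MTT assay, with a stated time of 5 days (a higher number here means that more compound is tolerated, a lower number that less compound is tolerated), compound 1 `N#Cc1ccc(Nc2nccc(Oc3ccc(-c4ccc(C#N)cc4)c(F)c3)n2)cc1` reaches only a limit of the assay, > 307000 nM. Compound 2 `Cc1cc(C#N)ccc1-c1ccc(Oc2ccnc(Nc3ccc(C#N)cc3)n2)c(F)c1` likewise gives only a limit in this assay, > 296000 nM. Neither of these is a number, so compound 2 stands exactly where compound 1 does: at the ceiling of what this assay can report, described by the limit of > 296000 nM in this assay, at which 1 of the 2 values shown sits, for compound 2 and by the limit of > 307000 nM in this assay, at which 1 of the 2 values shown sits, for compound 1. Compound 3 `Cc1cc(-c2ccc(Oc3ccnc(Nc4ccc(C#N)cc4)n3)c(F)c2)ccc1C#N` has the same atoms as compound 2, joined differently: 4-cyano-3-methylphenyl in place of 4-cyano-2-methylphenyl on an aromatic carbon. Among the measured compounds shown here, no measured pair shows what such a change does in this assay, and the step from compound 2 to compound 3 is expected to be none beyond the usual scatter. The expected step that the limit leaves unreadable from compound 2 to compound 3 therefore amounts to no real change. Compound 3 is expected to give 300000 nM in this assay, within a range from 150000 nM to 600000 nM, most likely again as a limit.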

Compound 3, half-maximal cytotoxic concentration: > 296000 nM
Compound 3: no number, only a limit (the forecaster's own chance of this, stated with the estimate: 85%); the middle value lies beyond the limit too.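

Compound 2 and compound 3 both reach only a limit in this assay, so no step can be read between them: the limit of > 296000 nM in this assay, at which 2 of the 3 values shown sit.

The compounds shown leave open at what concentration any of them harms these cells, and whether 4-cyano-3-methylphenyl in place of 4-cyano-2-methylphenyl changes that concentration at all.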